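This account rests on a few compounds, and the source may have more. Where it says the series, first, only, none or still open, it means among the compounds named here.

Compound 1 `O=C(O)c1ccccc1-c1ccc(CCc2ncc(CC3CCCCC3)[nH]2)cc1`: 41 nM
Compound 2 `O=C(O)c1ccccc1-c1ccc(CCc2ncc(Cc3ccccc3Cl)[nH]2)cc1`: 292 nM
Compound 3 `O=C(O)c1ccccc1-c1ccc(CCc2ncc(CCc3ccccc3)[nH]2)cc1`: 1320 nM

In an in vitro functional assay on cells for agonist activity at Bombesin receptor subtype-3 (Homo sapiens), read by luminescence and calcium flux (on this read-out higher numbers stand for an effect only at larger amounts of compound and lower numbers for an effect already at smaller amounts), compound 3 gives the highest number of the three; the steps of a 4.5-fold higher number from compound 2 to compound 3 (0.66 log units; beyond the scatter) and a 32-fold higher number from compound 1 to compound 3 (1.51 log units; beyond the scatter) both lie beyond the scatter. Compound 4 `O=C(O)c1ccccc1-c1ccc(CCc2ncc(Cc3ccc(F)cc3)[nH]2)cc1` differs from compound 3 by 4-fluorophenyl in place of benzyl on a saturated chain carbon bound to an aromatic carbon. Within the data shown here, no measured step keeps the benzyl group and adds a fluorine to it; the measured steps of a 7.1-fold higher number from compound 1 to compound 2 (0.85 log units; beyond the scatter) and a 4.5-fold higher number from compound 2 to compound 3 (0.66 log units; beyond the scatter) each exchange the whole group, so they bear on the change only loosely and give no firm direction. The fluorine is therefore expected to move the number little, within the scatter or at most a small step, and the estimate reads a 1.5-fold lower number from compound 3 to compound 4 (0.17 log units; within the scatter). Compound 4 is estimated at 900 nM, range 300 nM to 3000 nM.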

Compound 4, half-maximal effective concentration: 1600 nM
The estimate for compound 4 lay 1.8-fold (0.25 log units) below the measured number, and the stated range covers the measured number.
By their numbers in this assay, from the lowest: compound 1; then compound 2; then compounds 3 and 4 (each within the scatter of the next).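

In this assay the phenethyl of compound 3 and the 4-fluorobenzyl of compound 4 cannot be told apart, with a 1.2-fold higher number from compound 3 to compound 4 (0.08 log units; within the scatter) as the step between them. Both sit well away from the other two groups at this place, with a 5.5-fold higher number from compound 2 to compound 4 (0.74 log units; beyond the scatter) and with a 39-fold higher number from compound 1 to compound 4 (1.59 log units; beyond the scatter) for the step from cyclohexyl, so compound 1 keeps the lowest number of the four and the 2-chlorophenyl of compound 2 does not fall in with the other aromatic groups. Going by these compounds, whether a longer chain ending in cyclohexyl, or an amine on that chain, holds the number of compound 1 stays open. No measurement shown accounts for these steps.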